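From Ethynyl to Furan-2-yl on an Open Chain

The source may report more compounds than this note shows. Statements on the series, on what has been measured and on what is new or still open speak of the compounds shown alone.

Going by the values given here, in a functional assay on U-373MG ATCC cells for inhibition, with U373 MG (Homo sapiens) as the target, read by MTT assay, with a stated time of 7 days (on this read-out higher numbers stand for weaker inhibition of growth and lower numbers for stronger inhibition of growth), compound 3 (`C#CC/N=N/Nc1[nH]cnc1C(N)=O`) gives 32000 nM and this is the only true number in the set. Compound 1 (`NC(=O)c1ncn2c(=O)n(Cc3ccco3)nnc12`) gives > 50000 nM which is a limit and not a number. Compound 2 (`NC(=O)c1ncn2c(=O)n(Cc3ccsc3)nnc12`) gives > 50000 nM which is likewise only a limit. The data therefore consist largely of the limit of > 50000 nM in this assay, at which 2 of the 3 values shown sit, and offer no second number for comparison.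

Compound 4 (`NC(=O)c1nc[nH]c1N/N=N/Cc1ccco1`) differs from compound 3 by one change: furan-2-yl in place of ethynyl on a saturated chain carbon bound to a double-bonded nitrogen with furan-2-yl in place of ethynyl on a saturated chain carbon bound to a double-bonded nitrogen. Among the compounds with values here, only one measured step involves this furan-2-yl group, where thiophen-3-yl replaces it and yields a step that the two limits leave unreadable from compound 1 to compound 2 with no size to carry over. That step also belongs to the shared core of the first two compounds and not to the open chain of compound 3.

With compound 3 at 32000 nM as the sole anchor, no step beyond the usual scatter is expected in this assay and any drift would most likely be toward weaker inhibition of growth. The expected change is a 1.1-fold higher number from compound 3 to compound 4 (0.05 log units; within the scatter) and no larger. For compound 4 the estimate is 36000 nM with an expected range from 15000 nM to 85000 nM on this read-out.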

Compound 4, concentration for 50% growth inhibition: > 50000 nM
Compound 4: only a limit was reported; the forecaster's own chance of this, stated with the estimate: 40%; middle value at least 1.3-fold (0.14 log units) from the limit.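

On the open chain, this assay now yields a step with a readable floor: furan-2-yl in place of ethynyl on a saturated chain carbon bound to a double-bonded nitrogen gives an at least 1.5-fold higher number from compound 3 to compound 4 (0.19 log units; that floor lies within the scatter) and no upper bound on its size. Going by these compounds alone, the only earlier step, on the shared core of compound 1 and compound 2, could not be read, so this is the first change in the set that carries any size at all, though a floor within the scatter does not establish a real difference between ethynyl and furan-2-yl. The value of compound 4 is a limit and not a number, and it places this open-chain compound with compound 1 and compound 2 at the same limit: the limit of > 50000 nM in this assay, at which 3 of the 4 values shown sit.

Going by these compounds, how far the true value of compound 4 lies beyond its limit stays open, and with it whether the step exceeds the scatter at all. Also open, on these data alone, is how an amine, a carboxylic acid or a longer chain would read on this saturated chain carbon bound to a double-bonded nitrogen.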